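The source may report more compounds than this note shows. Statements on the series, on what has been measured and on what is new or still open speak of the compounds shown alone.

Within the data shown here, compound 1 `Cc1ccc(N2CCN(C(=O)c3oc(C)nc3-c3ccccc3)CC2)c(C)c1` is the only member of this small set with a numeric read-out. Among the measured compounds shown here, in a functional assay on HL-60 cells (Homo sapiens) for inhibition, read by MTT assay, with a stated time of 72 h (on this read-out higher numbers stand for weaker inhibition and lower numbers for stronger inhibition), compound 1 gives 101 nM, which is the single measured value and therefore the point of reference; nothing else here can be ranked against it. For the measured compounds named here, compound 2 `O=C(c1oc(C2CCCCC2)nc1-c1ccccc1F)N1CCN(c2cccc(Cl)c2)CC1` is the other measured entry, and in this assay compound 2 is reported as "not active" (no number reported), without a number, so no size of step between compound 1 and compound 2 can be stated.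

The unmeasured compound 3 `Cc1nc(-c2ccccc2)c(C(=O)N2CCN(c3cccc(F)c3)CC2)o1` keeps the shared core of compound 1 and differs from it in one place: 3-fluorophenyl in place of 2,4-dimethylphenyl on an amine nitrogen in a ring. Going by the values given here, no step between measured compounds is available to calibrate this change. Among the compounds with values here, with only one number in hand, the author expects a modest weakening rather than none, and expects the step from compound 1 to compound 3 to be a 3.0-fold higher number from compound 1 to compound 3 (0.47 log units; beyond the scatter), slightly beyond the scatter. For compound 3 the expected value in this assay is estimated at 300 nM, within a range from 100 nM to 1500 nM.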

Compound 3, half-maximal inhibitory concentration: 45 nM
For compound 3 the middle estimate is 6.7-fold (0.82 log units) above the measured one, outside the stated range (below it).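

In this assay, among these compounds, the exchange of 2,4-dimethylphenyl for 3-fluorophenyl on the amine nitrogen of the six-membered ring gives a 2.2-fold lower number from compound 1 to compound 3 (0.35 log units; beyond the scatter), the first step that can be read at this position. It shows that this position accepts a smaller aryl group carrying a fluorine in place of the two methyl groups, with the number moving modestly toward stronger inhibition; the step to or from compound 2, which has no number, cannot be read. Among the compounds shown here, nothing measured here accounts for this step, and the single exchange removes two methyl groups and adds a fluorine at once, so the step cannot be divided between them.

The compounds shown leave open how an unsubstituted phenyl or a methoxyphenyl would read on that nitrogen, and such groups would help separate the loss of the methyl groups from the arrival of the fluorine. From the compounds shown here alone, it also remains open whether the step would keep its direction and size if an ethyl group or an amine stood in place of the methyl on the shared core.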